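This account rests on a few compounds, and the source may have more. Where it says the series, first, only, none or still open, it means among the compounds named here.

In a functional assay on the whole organism with Scenedesmus acutus as the target, with a stated time of 20 h (on this read-out higher numbers stand for weaker inhibition and lower numbers for stronger inhibition), compound 1 (`O=C(O)c1cc(N2C(=O)C3=C(CCCC3)C2=O)c(F)cc1Cl`) gives 3160 nM, compound 2 (`CCOC(=O)c1cc(N2C(=O)C3=C(CCCC3)C2=O)c(F)cc1Cl`) gives 87.1 nM, and compound 3 (`CC(C)OC(=O)c1cc(N2C(=O)C3=C(CCCC3)C2=O)ccc1Cl`) gives 182 nM. Compound 3 therefore holds the second highest of the three numbers, with compound 2 lower and compound 1 much higher.

The next compound, compound 4 (`CC(C)OC(=O)c1cc(N2C(=O)C3=C(CCCC3)C2=O)c(F)cc1Cl`), keeps the isopropoxycarbonyl group of compound 3 and adds a single change, fluoro in place of hydrogen on an aromatic carbon.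

Within the data shown here, no measured step isolates this change. The only one available, a 36-fold lower number from compound 1 to compound 2 (1.56 log units; beyond the scatter), is large, but it concerns the group on the oxygen next to the carbonyl, and both of its compounds already carry the fluoro group. It therefore says little about the size of the new step. The closest guide is compound 2, at 87.1 nM, which has the fluoro group but an ethyl in place of the isopropyl. Its number lies only modestly below that of compound 3, and the two compounds differ in two places.

A small move toward a lower number is therefore expected, close to the usual scatter. The expected change is a 1.8-fold lower number from compound 3 to compound 4 (0.26 log units; within the scatter). For compound 4 the estimate is 100 nM, with an expected range from 40 nM to 250 nM.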

Compound 4, half-maximal inhibitory concentration: 89.1 nM
Compound 4: the middle estimate sits 1.1-fold (0.05 log units) above what was measured, within the range that was stated.
By their numbers in this assay, from the lowest: compounds 2 and 4 (each within the scatter of the next); then compound 3; then compound 1.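

In this assay, fluoro in place of hydrogen on an aromatic carbon, ortho to a large group, meta to a chloro group and para to an isopropoxycarbonyl group, now has a measured size of its own (a 2.0-fold lower number from compound 3 to compound 4 (0.31 log units; beyond the scatter)), a modest step that only just clears the scatter. With the fluoro group in place, the compounds with ethyl and isopropyl on the oxygen next to the carbonyl group cannot be told apart in this read-out (a 1.0-fold higher number from compound 2 to compound 4 (0.01 log units; within the scatter)). The large gain over the free carboxylic acid of compound 1 therefore appears with isopropyl (a 35-fold lower number from compound 1 to compound 4 (1.55 log units; beyond the scatter)) as it did with ethyl (a 36-fold lower number from compound 1 to compound 2 (1.56 log units; beyond the scatter)), and among these compounds it does not depend on which of the two chains is present.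

Nothing measured here gives a reason for the size of any of these steps. On these data alone, it remains open whether another group at this aromatic carbon, such as methoxy or nitrile, would match fluoro, and whether a longer chain on the oxygen, such as n-butyl, would keep the number at the level of compound 2 and compound 4.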